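This account rests on a few compounds, and the source may have more. Where it says the series, first, only, none or still open, it means among the compounds named here.

Compound 1 `O=C(/C=C(O)/C=C/c1ccc(O)cc1)c1ccccc1O`: 20.4%
Compound 2 `O=C(/C=C(O)/C=C/c1ccc(O)c(O)c1)c1ccccc1O`: 93.6%

In an assay on isolated protein for inhibition of Alpha glucosidase (Homo sapiens), with stated times of 5 min and 15 min, tested at 50 uM (on this read-out higher numbers stand for more inhibition at the one concentration tested (going by the name of the read-out) and lower numbers for less inhibition), compound 2 gives the highest of the two numbers; compound 1 gives a number a number 73.2 percentage points higher from compound 1 to compound 2 (beyond the scatter). Compound 3 `O=C(/C=C(O)/C=C/c1cccc(O)c1)c1ccccc1O` differs from compound 2 by hydrogen in place of hydroxy on an aromatic carbon. Going by the values given here, the only measured step, a number 73.2 percentage points higher from compound 1 to compound 2 (beyond the scatter), shows that adding a hydroxy to this ring raised the read-out greatly; taking one away from compound 2 is therefore expected to lower it well beyond the scatter, though compound 3 is not simply compound 1. The expected step is a number 58.6 percentage points lower from compound 2 to compound 3 (beyond the scatter). Compound 3 is estimated at 35%, in the range 10% to 65%.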

Compound 3, a percentage reported as inhibition, at one concentration (the size of the read-out at that concentration, not a potency): 40.4%
Compound 3: the middle estimate sits 5.4 percentage points below what was measured; the range from low to high includes it.
By their numbers in this assay, from the lowest: compound 1; then compound 3; then compound 2.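

Losing the hydroxy para to a large group costs as much as the earlier step suggested: a number 53.2 percentage points lower from compound 2 to compound 3 (beyond the scatter) in this assay. So each of the two hydroxy groups of compound 2 counts, and neither alone restores its read-out. With a single hydroxy, its place on the ring also matters, as 3-hydroxyphenyl in place of 4-hydroxyphenyl gives a number 20 percentage points higher from compound 1 to compound 3 (beyond the scatter), a modest step beside the large one. Going by these compounds, whether a methoxy group or an amine could stand in for either hydroxy remains open. No outside data explain these steps.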